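A few compounds are considered here, and "the series" means these few. Any claim that something is new, unique, unknown or untested is made for them only; others in the source may bear on it.

Of the compounds shown here, three sharing one core have been tested in an ADME assay on the whole organism with Oryza sativa as the target, tested at 1 uM; on this read-out higher numbers stand for a weaker effect at the one concentration tested and lower numbers for a stronger effect. Compound 1 `CCc1ccc(NC(=O)N[C@H](C)c2ccccc2)cc1` gives 47%, compound 2 `C[C@@H](NC(=O)Nc1ccc(C(F)(F)F)cc1)c1ccccc1` gives 89%, and compound 3 `CC(=O)c1ccc(NC(=O)N[C@H](C)c2ccccc2)cc1` gives 93%, the highest of the three numbers; its gap to compound 2 lies within the scatter, while a number 46 percentage points higher from compound 1 to compound 3 (beyond the scatter) lies beyond it. Compound 4 `C[C@@H](NC(=O)Nc1ccc(I)cc1)c1ccccc1` differs from compound 3 in one place: iodo in place of acetyl on an aromatic carbon. Among the compounds with values here, no measured step involves iodo. The steps of a number 42 percentage points higher from compound 1 to compound 2 (beyond the scatter) and a number 46 percentage points higher from compound 1 to compound 3 (beyond the scatter) were large, whereas a number 4 percentage points higher from compound 2 to compound 3 (within the scatter) stayed within the scatter, so two different groups at this place gave much the same number. A modest downward step a number 15 percentage points lower from compound 3 to compound 4 (beyond the scatter) is therefore expected, with wide uncertainty. Compound 4 is estimated at 78%, within 55% to 95%.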

Compound 4, a percentage reported as activity, at one concentration (the size of the read-out at that concentration, not a potency): 91%
Compound 4: middle estimate off by 13 percentage points, on the low side; the measured number falls inside the stated range.
By their numbers in this assay, from the lowest: compound 1; then compounds 2, 4 and 3 (each within the scatter of the next).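

In this assay, iodo behaves like trifluoromethyl and acetyl at this place on the ring: a number 2 percentage points lower from compound 3 to compound 4 (within the scatter) and a number 2 percentage points higher from compound 2 to compound 4 (within the scatter) both stay within the scatter, so three different groups now give numbers that cannot be told apart. Ethyl alone stands apart, with a number 44 percentage points higher from compound 1 to compound 4 (beyond the scatter). Iodo, a single atom, matches acetyl with its three heavy atoms, so among these compounds size by atom count does not separate the numbers. From the compounds shown here alone, whether the lower number belongs to ethyl alone or extends to a methyl, a longer chain or an amine remains open. Nothing available explains why ethyl differs from the other three groups.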